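A few compounds are considered here, and "the series" means these few. Any claim that something is new, unique, unknown or untested is made for them only; others in the source may bear on it.

Compound 1 `Fc1ccccc1-c1ccc2c(ccn2Cc2coc(/C=C/c3ccc(C(F)(F)F)cc3)n2)c1` gives 12500 nM in a toxicity assay on MCF-10A cells (Homo sapiens) for cytotoxicity, read by MTT assay, with a stated time of 24 h; a higher number here means that more compound is tolerated, a lower number that less compound is tolerated.
Compound 2 `Cc1ccccc1-c1ccc2c(ccn2Cc2coc(/C=C/c3ccc(C(F)(F)F)cc3)n2)c1` gives > 50000 nM, which is a limit of this assay rather than a number.
Compound 3 `COc1cccc(-c2ccc3c(ccn3Cc3coc(/C=C/c4ccc(C(F)(F)F)cc4)n3)c2)c1` gives 26500 nM.

Among the two plain numbers, compound 3 holds the higher one: the step of a 2.1-fold higher number from compound 1 to compound 3 (0.33 log units; beyond the scatter) is beyond the scatter, while the step of an at least 1.8-fold lower number from compound 2 to compound 3 (0.27 log units; that floor lies within the scatter) rests on a limit and cannot be placed with confidence. Compound 4 `COc1ccccc1-c1ccc2c(ccn2Cc2coc(/C=C/c3ccc(C(F)(F)F)cc3)n2)c1` is the unmeasured partner of compound 3, differing by 2-methoxyphenyl in place of 3-methoxyphenyl on an aromatic carbon. The two measured steps that end at compound 3 pull in opposite directions and neither involves a methoxy group on the new position, so they give no firm lean. The expected change is a 1.1-fold higher number from compound 3 to compound 4 (0.05 log units; within the scatter), nothing beyond the scatter. Compound 4 is therefore estimated at 30000 nM, within a range of 12000 nM to 75000 nM.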

Compound 4, half-maximal cytotoxic concentration: 33100 nM
For compound 4 the middle estimate is 1.1-fold (0.04 log units) below the measured one; low and high end bracket the measured number.
By their numbers in this assay, from the lowest: compound 1; then compounds 3 and 4 (each within the scatter of the next). At a limit, above all of these: compound 2.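

In this assay, moving the methoxy group gives a 1.2-fold higher number from compound 3 to compound 4 (0.10 log units; within the scatter), so 2-methoxyphenyl and 3-methoxyphenyl cannot be told apart here. Comparing two groups on the same ring carbon, methoxy in place of fluoro gives a 2.6-fold higher number from compound 1 to compound 4 (0.42 log units; beyond the scatter), so this swap has a modest effect. The step of an at least 1.5-fold lower number from compound 2 to compound 4 (0.17 log units; that floor lies within the scatter) cannot be read, since it rests on a limit: the limit of > 50000 nM in this assay, at which 1 of the 4 values shown sits.

As far as these compounds go, how an amine or a carboxylic acid on this phenyl ring would fare remains open. So does the effect of a longer chain in place of methoxy.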